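Methoxy added to the carbamate aryl ring of compound 3

The compounds below may be only part of what the source reports. "The series", "measured", "known", "first", "only" and "open" are said of these compounds alone.

Three compounds of the series carry numbers in an assay on liver for inhibition of sterol O-acyltransferase 1 (Rattus norvegicus), using microsomes; on this read-out lower numbers stand for stronger inhibition and higher numbers for weaker inhibition. Compound 1 `CC(C)c1cccc(C(C)C)c1NC(=O)NS(=O)(=O)N1CCCC1` gives 15000 nM. Among the measured compounds shown here, compound 2 `C=CCN(CC=C)S(=O)(=O)NC(=O)Nc1c(C(C)C)cccc1C(C)C` gives 2700 nM; the one single-point step measured so far, a 5.6-fold lower number from compound 1 to compound 2 (0.74 log units; beyond the scatter), changes only the group on the sulfonyl sulfur. Compound 3 `CC(C)c1cccc(C(C)C)c1NS(=O)(=O)NC(=O)Oc1c(C(C)(C)C)cccc1C(C)(C)C` gives 16800 nM, the highest of the three numbers; compound 1 sits within the scatter of it, compound 2 beyond it.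

Compound 4 `COc1cc(C(C)(C)C)c(OC(=O)NS(=O)(=O)Nc2c(C(C)C)cccc2C(C)C)c(C(C)(C)C)c1` differs from compound 3 in one place: methoxy in place of hydrogen on an aromatic carbon of the carbamate-bearing ring. For the measured compounds named here, no measured step touches this ring; the step from compound 1 to compound 2 concerns a different part of the shared core and gives no guidance on a methoxy here. With nothing in the series pointing either way, the expected change from compound 3 to compound 4 is none beyond the scatter, a 1.1-fold lower number from compound 3 to compound 4 (0.05 log units; within the scatter). Compound 4 is therefore estimated at 15000 nM, with a range of 5000 nM to 45000 nM.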

Compound 4, half-maximal inhibitory concentration: 15000 nM
Estimate against measurement, compound 4: no gap at the digits printed, within the range that was stated.
By their numbers in this assay, from the lowest: compound 2; then compounds 1, 4 and 3 (each within the scatter of the next).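

In this assay, methoxy in place of hydrogen on an aromatic carbon, meta to two tert-butyl groups and para to a large group, gives a 1.1-fold lower number from compound 3 to compound 4 (0.05 log units; within the scatter), so this position takes the added group with no change that can be read. This is the first step shown on the carbamate aryl ring, and it gives that ring a flat result at this one carbon, whereas the only earlier step concerned the group on the sulfonyl sulfur. No data shown bear on why the value holds here.

On these data alone, whether this carbon stays as flat for a carboxylic acid or an amine remains open. A longer chain on the same oxygen, such as butoxy, is equally untested by the compounds shown here.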